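The compounds below may be only part of what the source reports. "The series", "measured", "known", "first", "only" and "open" are said of these compounds alone.

Measured compounds:
compound 1, `COC(=O)[C@H](CO)NC(=O)/C=C/c1ccc(OC)cc1`, 103%
compound 2, `O=C(/C=C/c1ccc(F)cc1)O/C(=N/C1CCCCC1)NC1CCCCC1`, 85.5%

Both were tested in an ADME assay on Vero cells (Chlorocebus sabaeus) for cytotoxicity, read by WST assay, tested at 100 ug/mL; on this read-out lower numbers stand for a stronger effect and higher numbers for a weaker effect at the one concentration tested. On the two numbers available compound 2 gives the lower read-out, and the nearest value, that of compound 1, stands higher by a gap that falls beyond the usual scatter; nothing more is said of that pair, since the two compounds differ in several places at once.

The step of interest leads from compound 2 to compound 3, `O=C(/C=C/c1ccccc1)O/C(=N/C1CCCCC1)NC1CCCCC1`, which has not yet been measured in this assay. The change is small: hydrogen in place of fluoro on an aromatic carbon. No comparable single-point change is available among the measured compounds, so the expectation rests on compound 2 alone.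

For compound 3 the expected outcome in this assay is a value close to that of compound 2, with a step of a number 4.5 percentage points higher from compound 2 to compound 3 (within the scatter) that should lie within the usual scatter. The estimate for compound 3 is 90%, with a range from 75% to 105%.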

Compound 3, a percentage reported as activity, at one concentration (the size of the read-out at that concentration, not a potency): 83.8%
Beside the measured number, compound 3's estimate is 6.2 percentage points above it; the measured number falls inside the stated range.
By their numbers in this assay, from the lowest: compounds 3 and 2 (each within the scatter of the next); then compound 1.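

In this assay, hydrogen in place of fluoro on an aromatic carbon para to a large group gives a step of a number 1.7 percentage points lower from compound 2 to compound 3 (within the scatter), so fluoro and hydrogen at this position cannot be told apart at the one concentration tested. This is the first change in a single place that can be read among these compounds, and it shows that the read-out seen with compound 2 does not depend on the fluoro. No measurement at hand offers an explanation for this result.

On these data alone, whether trifluoromethyl, an amine or a carboxylic acid at the same position would shift the read-out remains open. Also open, as far as these compounds go, is how the read-out would respond to a change elsewhere in the shared core, such as a longer chain in place of a cyclohexyl group.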